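The source may hold more compounds than are shown below. What is called first, only, known or untested is meant among the compounds shown, and "the series" means these compounds.

Two members of the series have been run in an ADME assay on PBMC cells (Homo sapiens) for cytotoxicity; a higher number here means that more compound is tolerated, a lower number that less compound is tolerated. Compound 1 `CC(CCNC(=O)c1c(Cl)cncc1Cl)N1CCC(C(Oc2cccc(F)c2)c2ccc(C(F)(F)F)cc2)CC1` gives 5400 nM, the lower of the two numbers shown. Compound 2 `CC(CCNC(=O)c1c(Cl)cncc1Cl)N1CCC(C(Oc2cccnc2)c2ccc(Br)cc2)CC1` gives 32500 nM, a gap beyond the usual scatter. Compound 3 `Cc1cccc(OC(c2ccc(C(F)(F)F)cc2)C2CCN(C(C)CCNC(=O)c3c(Cl)cncc3Cl)CC2)n1` has not yet been measured in this assay. It differs from compound 1 in one place: 6-methylpyridin-2-yl in place of 3-fluorophenyl on an oxygen on a saturated carbon. Within the data shown here, no measured pair shows this change alone, so the expectation leans on compound 2 standing at 32500 nM. The step of a 1.7-fold higher number from compound 1 to compound 3 (0.22 log units; within the scatter) is the expected one, a modest rise in tolerated concentration, within the scatter or just beyond it. For compound 3 the estimate is 9000 nM, with a range of 3500 nM to 25000 nM.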

Compound 3, half-maximal cytotoxic concentration: 6700 nM
Beside the measured number, compound 3's estimate is 1.3-fold (0.13 log units) above it; measured number inside the range.
By their numbers in this assay, from the lowest: compounds 1 and 3 (each within the scatter of the next); then compound 2.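

Where 3-fluorophenyl on the oxygen gives way to 6-methylpyridin-2-yl, this assay shows a 1.2-fold higher number from compound 1 to compound 3 (0.09 log units; within the scatter). This exchange of a carbon-only aromatic ring for one with a ring nitrogen and a hydrogen-bond acceptor therefore leaves compounds 1 and 3 indistinguishable at this position.

Compound 2 differs from compound 1 in more than one place, so its number cannot be assigned to any single group. On these data alone, whether an amine or a carboxylic acid on the group at this oxygen would separate from compounds 1 and 3 remains open. No measurement here offers an explanation for this result.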